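Fluoro in Place of Hydrogen on the Anilino Ring

The source may hold more compounds than are shown below. What is called first, only, known or untested is meant among the compounds shown, and "the series" means these compounds.

Measured compounds:
compound 1, `C=C1[C@@H](OC(C)=O)C[C@@H]2[C@](C)(CO[Si](C)(C)C(C)(C)C)[C@H](OC(C)=O)CC[C@@]2(C)[C@@H]1C[C@@H](Nc1ccccc1)C1=CCOC1=O`: 4500 nM
compound 2, `C=C1[C@@H](OC(C)=O)C[C@@H]2[C@](C)(COC=O)[C@H](OC(C)=O)CC[C@@]2(C)[C@@H]1C[C@@H](Nc1ccccc1C(=O)O)C1=CCOC1=O`: 45900 nM
compound 3, `C=C1[C@@H](OC(C)=O)C[C@@H]2[C@](C)(COC=O)[C@H](OC(C)=O)CC[C@@]2(C)[C@@H]1C[C@@H](Nc1ccc(OC)c(OC)c1)C1=CCOC1=O`: > 50000 nM, a limit of the assay

In a functional assay on A549 cells (Homo sapiens) for cytotoxicity, read by sulforhodamine B assay (a higher number here means a weaker inhibitor, a lower number a stronger inhibitor), compound 1 gives 4500 nM, the lowest of the two numbers shown. Compound 2 gives 45900 nM, a higher number whose gap to compound 1 lies beyond the scatter. For compound 3 the assay reports only a limit, (the limit of > 50000 nM in this assay, at which 1 of the 3 values shown sits).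

Among the measured compounds shown here, the one measured step on the anilino ring is an at least 1.0-fold higher number from compound 2 to compound 3 (0.03 log units; that floor lies within the scatter), where 3,4-dimethoxyphenyl replaces 2-carboxyphenyl on the amine nitrogen; its floor lies within the scatter, and since it ends at a limit its true size is unknown.

Compound 4, `C=C1[C@@H](OC(C)=O)C[C@@H]2[C@](C)(CO[Si](C)(C)C(C)(C)C)[C@H](OC(C)=O)CC[C@@]2(C)[C@@H]1C[C@@H](Nc1cccc(F)c1)C1=CCOC1=O`, differs from compound 1 as follows: fluoro in place of hydrogen on an aromatic carbon. For the measured compounds named here, no measured step replaces hydrogen with fluoro, so the only guide is that the one change on this ring gave no step beyond its floor. A small step, or none beyond the scatter, is therefore expected, with the direction open.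

For compound 4 the expected value in this assay is 5000 nM, within 2000 nM to 12500 nM. That estimate means a step of a 1.1-fold higher number from compound 1 to compound 4 (0.05 log units; within the scatter), expected to stay within the scatter.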

Compound 4, half-maximal inhibitory concentration: 4060 nM
Beside the measured number, compound 4's estimate is 1.2-fold (0.09 log units) above it; measured number inside the range.
By their numbers in this assay, from the lowest: compounds 4 and 1 (each within the scatter of the next); then compound 2. At a limit, above all of these: compound 3.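

The step of a 1.1-fold lower number from compound 1 to compound 4 (0.04 log units; within the scatter) comes with fluoro in place of hydrogen on an aromatic carbon of the anilino ring, meta to a large group, and it shows that in this assay this position takes a fluoro with no change beyond the scatter. The earlier step on this ring ended at a limit and gave only a floor, whereas this one has a measured number at both ends, so its size can be read: a single added fluorine leaves the number where it was, within the scatter, with the rest of compound 1 held fixed. Nothing in the data shown bears on why the number stays there.

From the compounds shown here alone, whether a chloro, a methoxy or an amine on the same carbon would also stay within the scatter remains open, as does whether fluoro on another carbon of the ring would behave alike. Going by these compounds, it is also open whether the same change would read the same way on compound 2, which differs from compound 1 in more than one place.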